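Estimating compound 4 from three measured analogues

The source may report more compounds than this note shows. Statements on the series, on what has been measured and on what is new or still open speak of the compounds shown alone.

Compound 1 `N#Cc1c(-c2ccccc2O)c(C#N)c(=O)n(/N=C/c2cn(-c3ccccc3)nc2-c2ccccc2)c1N` gives 162 ug/mL in an ADME assay on NIH3T3 cells (Mus musculus) for cytotoxicity, read by MTT assay (on this read-out higher numbers stand for weaker inhibition and lower numbers for stronger inhibition), and compound 2 `Cc1ccc(-c2c(C#N)c(N)n(/N=C/c3cn(-c4ccccc4)nc3-c3ccccc3)c(=O)c2C#N)cc1` gives 98 ug/mL. For compound 3 `N#Cc1c(-c2ccccc2[N+](=O)[O-])c(C#N)c(=O)n(/N=C/c2cn(-c3ccccc3)nc2-c2ccccc2)c1N` the reading is only a limit, > 200 ug/mL, the assay ceiling recorded as the limit of > 200 ug/mL in this assay, at which 1 of the 3 values shown sits. Compound 4 `N#Cc1c(-c2ccc(Br)cc2)c(C#N)c(=O)n(/N=C/c2cn(-c3ccccc3)nc2-c2ccccc2)c1N` differs from compound 3 in one place: 4-bromophenyl in place of 2-nitrophenyl on an aromatic carbon. The measured steps reaching compound 3 are an at least 1.2-fold higher number from compound 1 to compound 3 (0.09 log units; that floor lies within the scatter) and an at least 2.0-fold higher number from compound 2 to compound 3 (0.30 log units; that floor lies within the scatter), both floors within the scatter, so compound 3 stands at the top of the numbers shown without a firm value. The step of an at least 1.6-fold lower number from compound 3 to compound 4 (0.22 log units; that floor lies within the scatter) is therefore expected to be modest, leaning lower because compound 2 with 4-methylphenyl gives 98 ug/mL. Compound 4 is estimated at 120 ug/mL, with a range from 65 ug/mL to 200 ug/mL.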

Compound 4, half-maximal inhibitory concentration: > 200 ug/mL
Compound 4: no number, only a limit; the forecaster's own chance of this, stated with the estimate: 25%; at least 1.6-fold (0.22 log units) between middle value and limit.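

In this assay, compound 4 also gives only a limit, so two different aryl groups at this position, opposite the ring nitrogen, now end at a limit and the step between compound 3 and compound 4 cannot be read: the limit of > 200 ug/mL in this assay, at which 2 of the 4 values shown sit. The remaining comparisons are an at least 2.0-fold higher number from compound 2 to compound 4 (0.30 log units; that floor lies within the scatter) and an at least 1.2-fold higher number from compound 1 to compound 4 (0.09 log units; that floor lies within the scatter). Neither separates compound 4 firmly from the compound it is compared with.

Going by these compounds, the actual numbers for compound 3 and compound 4 stay open. So does whether an amine or a carboxylic acid in place of the bromine would give a firm reading.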